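A few compounds are considered here, and "the series" means these few. Any claim that something is new, unique, unknown or untested is made for them only; others in the source may bear on it.

Measured so far in a functional assay on HeLa cells (Homo sapiens) for cytotoxicity, read by MTT assay, with a stated time of 24 h; on this read-out higher numbers stand for weaker inhibition and lower numbers for stronger inhibition

- compound 1 `COc1ccc(/C=C2\CN(C)C/C(=C\c3ccccc3F)C2=O)cc1` gives 23500 nM
- compound 2 `CN1C/C(=C\c2ccc(C(C)(C)C)cc2)C(=O)/C(=C/c2ccccc2F)C1` gives 15500 nM
- compound 3 `CN1C/C(=C\c2ccc(C#N)cc2)C(=O)/C(=C/c2ccccc2F)C1` gives 1340 nM
- compound 4 `CN1C/C(=C\c2ccc(Cl)cc2)C(=O)/C(=C/c2ccc(C#N)cc2)C1` has not been measured yet

Compound 3 has the lowest number of the three, at 1340 nM, and both of its steps to the others lie beyond the scatter. Going on to compound 4 keeps the cyano group of compound 3 and makes one change: 4-chlorophenyl in place of 2-fluorophenyl on a double-bonded chain carbon bound to a double-bonded ring carbon. Among the measured compounds shown here, no measured step touches the 2-fluorophenyl group, so the evidence is only indirect. The available steps all swap a group on the other aromatic ring. There is a 1.5-fold lower number from compound 1 to compound 2 (0.18 log units; within the scatter), but also an 18-fold lower number from compound 1 to compound 3 (1.24 log units; beyond the scatter) and a 12-fold lower number from compound 2 to compound 3 (1.06 log units; beyond the scatter). Among these three compounds, then, one swap can leave the number in place or shift it strongly, and none of them points a direction for the new swap. The expected change is a 1.1-fold higher number from compound 3 to compound 4 (0.05 log units; within the scatter), an estimate that stays within the scatter. The estimated value for compound 4 is 1500 nM, with an expected range from 400 nM to 6000 nM.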

Compound 4, half-maximal inhibitory concentration: 11200 nM
For compound 4 the middle estimate is 7.5-fold (0.87 log units) below the measured one, outside the stated range (above it).
By their numbers in this assay, from the lowest: compound 3; then compounds 4, 2 and 1 (each within the scatter of the next, the first and the last beyond it).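

The earlier steps shown here all changed the other aromatic ring, but in this assay this swap of 2-fluorophenyl for 4-chlorophenyl gives an 8.4-fold higher number from compound 3 to compound 4 (0.92 log units; beyond the scatter), a step beyond the scatter, so this position also affects the read-out. The cyano group is present in both compound 3 and compound 4, so its presence alone does not secure the low number of compound 3. Nothing measured here offers an explanation for this step.

The two groups differ both in their halogen and in where it sits on the ring, and the compounds shown cannot tell these two differences apart. As far as these compounds go, how a phenyl ring carrying an amine or a carboxylic acid would behave at this position also remains open.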